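Swapping the Aryl Substituent Pattern on a Cytotoxic Core

The compounds below may be only part of what the source reports. "The series", "measured", "known", "first", "only" and "open" are said of these compounds alone.

Compound 1 `C=CCn1c(=O)/c(=C\c2ccccc2Cl)[nH]c(=O)/c1=C\c1ccccc1OC`: 2500 nM
Compound 2 `C=CCn1c(=O)/c(=C\c2ccccc2OC)[nH]c(=O)/c1=C\c1ccccc1OC`: 7400 nM
Compound 3 `C=CCn1c(=O)/c(=C\c2ccccc2C(F)(F)F)[nH]c(=O)/c1=C\c1ccccc1OC`: 2700 nM

In a functional assay on K562 cells (Homo sapiens) for cytotoxicity, read by CCK-8 assay, with a stated time of 72 h (a higher number here means a weaker inhibitor, a lower number a stronger inhibitor), compound 3 holds the second highest of the three numbers; compound 1 lies within the scatter of it, as a 1.1-fold higher number from compound 1 to compound 3 (0.03 log units; within the scatter) shows, while compound 2 lies beyond it, as a 2.7-fold lower number from compound 2 to compound 3 (0.44 log units; beyond the scatter) shows. Compound 4 `C=CCn1c(=O)/c(=C\c2ccc(F)c(Br)c2)[nH]c(=O)/c1=C\c1ccccc1OC` differs from compound 3 by 3-bromo-4-fluorophenyl in place of 2-(trifluoromethyl)phenyl on a double-bonded chain carbon bound to an aromatic carbon. Within the data shown here, every measured step exchanged only the single group on that ring: a 3.0-fold higher number from compound 1 to compound 2 (0.47 log units; beyond the scatter) was modest, and a 1.1-fold higher number from compound 1 to compound 3 (0.03 log units; within the scatter) stayed within the scatter. Among the measured compounds shown here, no measured step moves the groups to other positions or introduces bromine, so these steps bear on the change only loosely; a step within the scatter or modestly higher is expected, a 1.3-fold higher number from compound 3 to compound 4 (0.11 log units; within the scatter). Compound 4 is therefore estimated at 3500 nM, within a range of 1200 nM to 10000 nM.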

Compound 4, half-maximal inhibitory concentration: "not active" (no number reported)
Compound 4 has no reported number here; no gap can be computed for the estimate.
By their numbers in this assay, from the lowest: compounds 1 and 3 (each within the scatter of the next); then compound 2.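

In this assay, among these compounds, compound 4 is reported only as "not active", without a number, so no step from compound 3 to compound 4 can be read. Nothing measured here explains that result. The compounds shown leave open whether the bromine, the fluorine or the changed substitution pattern of 3-bromo-4-fluorophenyl accounts for it.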